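Solubility notes: aryl amine variation on the shared core

The source may report more compounds than this note shows. Statements on the series, on what has been measured and on what is new or still open speak of the compounds shown alone.

Compound 1 `CNC(=O)c1cc(Oc2ccc3nc(Nc4ccccc4)ncc3c2)ccn1` gives < 1000 nM in a physicochemical assay for solubility, at pH 7 (a lower number here means a less soluble compound, a higher number a more soluble compound), a limit of the assay.
Compound 2 `CNC(=O)c1cc(Oc2ccc3nc(Nc4cccc(C(F)(F)F)c4)ncc3c2)ccn1` gives < 1000 nM in this assay, also a limit.
Compound 3 `CNC(=O)c1cc(Oc2ccc3nc(Nc4cccc(OC(F)(F)F)c4)ncc3c2)ccn1` gives < 1000 nM in this assay, again a limit.

Compound 3 thus stands at the limit of < 1000 nM in this assay, at which 3 of the 3 values shown sit, alongside the other two. The steps a step that the two limits leave unreadable from compound 1 to compound 3 and a step that the two limits leave unreadable from compound 2 to compound 3 cannot be sized, and neither can a step that the two limits leave unreadable from compound 1 to compound 2. Compound 4 `CNC(=O)c1cc(Oc2ccc3nc(Nc4ccc(C(C)C)cc4)ncc3c2)ccn1` carries 4-isopropylphenyl in place of 3-(trifluoromethoxy)phenyl on a nitrogen on an aromatic ring. With no readable step among the three measured compounds, the expected step that the limit leaves unreadable from compound 3 to compound 4 has no measured anchor and is taken as roughly flat. Compound 4 is expected to give 500 nM in this assay, within a range of 100 nM to 2000 nM, most likely reported again as a limit.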

Compound 4, solubility: < 1000 nM
Compound 4 was reported as a limit; the forecaster's own chance of this, stated with the estimate: 80%; the middle value is on the limit's open side.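

For the compounds shown here, compound 4 also gives only a limit in this assay, so no step among compound 1, compound 2, compound 3 and compound 4 can be read: the limit of < 1000 nM in this assay, at which 4 of the 4 values shown sit. Whether any of these aryl groups on the nitrogen changes solubility remains open, as the compounds shown give no value beyond this limit.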